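Saturating the Chain and Exchanging the Aryl Group

The source may report more compounds than this note shows. Statements on the series, on what has been measured and on what is new or still open speak of the compounds shown alone.

Three measured compounds share one core and differ only in the aryl group on the double-bonded chain. In an assay on cells for inhibition of Ectonucleotide pyrophosphatase/phosphodiesterase family member 1 (Homo sapiens), with a stated time of 60 min, tested at 1 uM (a higher number here means more inhibition at the concentration tested (going by the name of the read-out), a lower number less inhibition), compound 3 `COc1cccc(/C=C/c2nc(N3CCC(CCNS(N)(=O)=O)CC3)c3cc(OC)c(OC)cc3n2)c1` gives 88%, the highest of the three numbers; compound 1 `COc1cc2nc(/C=C/c3ccccc3F)nc(N3CCC(CCNS(N)(=O)=O)CC3)c2cc1OC` gives 78%, and compound 2 `COc1cc2nc(/C=C/c3ccc(F)cc3)nc(N3CCC(CCNS(N)(=O)=O)CC3)c2cc1OC` gives 70%. The step of a number 10 percentage points higher from compound 1 to compound 3 (within the scatter) lies within the scatter, whereas a number 18 percentage points higher from compound 2 to compound 3 (beyond the scatter) is beyond it. Compound 4 `COc1cc2nc(CCc3ccc(F)cc3)nc(N3CCC(CCNS(N)(=O)=O)CC3)c2cc1OC` differs from compound 3 by 2-(4-fluorophenyl)ethyl in place of 2-(3-methoxyphenyl)ethenyl on an aromatic carbon. Within the data shown here, the aryl exchange is covered by a number 18 percentage points higher from compound 2 to compound 3 (beyond the scatter), a modest gain that should reverse here; the loss of the double bond outside aromatic rings is covered by no measured step. The expected step is therefore a number 33 percentage points lower from compound 3 to compound 4 (beyond the scatter). Compound 4 is expected to give 55% in this assay, between 30% and 78%.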

Compound 4, a percentage reported as inhibition, at one concentration (the size of the read-out at that concentration, not a potency): 69%
Compound 4: the middle estimate sits 14 percentage points below what was measured, within the range that was stated.
By their numbers in this assay, from the lowest: compounds 4, 2, 1 and 3 (each within the scatter of the next, the first and the last beyond it).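

Exchanging 2-(4-fluorophenyl)ethenyl for 2-(4-fluorophenyl)ethyl gives a number 1 percentage points lower from compound 2 to compound 4 (within the scatter), so in this assay the double bond outside aromatic rings can be lost on this aromatic carbon without a readable change when the aryl group is 4-fluorophenyl. The step of a number 9 percentage points lower from compound 1 to compound 4 (within the scatter) also stays small, whereas a number 19 percentage points lower from compound 3 to compound 4 (beyond the scatter) is close in size to a number 18 percentage points higher from compound 2 to compound 3 (beyond the scatter), so the loss appears only against the 3-methoxyphenyl compound. No supporting evidence bears on this result. On these data alone, whether 2-(3-methoxyphenyl)ethyl would hold the level of compound 3 stays open, as does the effect of a longer propyl chain or an amine on the aryl ring.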